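Capping the piperazine: toxicity expectation for compound 4

A few compounds are considered here, and "the series" means these few. Any claim that something is new, unique, unknown or untested is made for them only; others in the source may bear on it.

Three compounds share one core. In an ADME assay on MT4 cells (Homo sapiens) for cytotoxicity, read by MTT assay, with a stated time of 5 days (on this read-out higher numbers stand for lower toxicity in this test and lower numbers for higher toxicity in this test), compound 1 `Cc1cc(/C=C/C#N)cc(C)c1Oc1nc(Nc2ccc(CN3CCN(S(C)(=O)=O)CC3)cc2)nc2ccsc12` gives 20700 nM, compound 2 `Cc1cc(/C=C/C#N)cc(C)c1Oc1nc(Nc2ccc(CN3CCNCC3)cc2)nc2ccsc12` gives 3970 nM, and compound 3 `Cc1cc(/C=C/C#N)cc(C)c1Oc1nc(Nc2ccc(CN3CCN(S(C)(=O)=O)CC3)cc2)nc2sccc12` gives 131000 nM. Compound 2 thus stands lowest of the three numbers. Among the measured compounds shown here, the one single-point step recorded, a 5.2-fold lower number from compound 1 to compound 2 (0.72 log units; beyond the scatter), came with hydrogen in place of methylsulfonyl on the ring amine nitrogen. Compound 4 `Cc1cc(/C=C/C#N)cc(C)c1Oc1nc(Nc2ccc(N3CCN(S(N)(=O)=O)CC3)cc2)nc2ccsc12` differs from compound 2 by 4-sulfamoylpiperazin-1-yl in place of (piperazin-1-yl)methyl on an aromatic carbon. Since compound 4 again carries a sulfonyl-type cap on that ring nitrogen, the step from compound 1 to compound 2 is the nearest guide, and a rise of similar size is expected, a 3.8-fold higher number from compound 2 to compound 4 (0.58 log units; beyond the scatter). Compound 4 is therefore estimated at 15000 nM, within a range of 5000 nM to 60000 nM.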

Compound 4, half-maximal cytotoxic concentration: > 222000 nM
Compound 4: a limit, no number; the forecaster's own chance of this, stated with the estimate: 15%; middle value at least 14-fold (1.17 log units) from the limit.
By their numbers in this assay, from the lowest: compound 2; then compound 1; then compound 3. At a limit, above all of these: compound 4.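

Compound 4 reads in this assay only as a limit, not as a number: the limit of > 222000 nM in this assay, at which 1 of the 4 values shown sits. Placing 4-sulfamoylpiperazin-1-yl on this aromatic carbon gives an at least 55-fold higher number from compound 2 to compound 4 (1.74 log units; beyond the scatter), and measured against the capped side chain it still gives an at least 10-fold higher number from compound 1 to compound 4 (1.03 log units; beyond the scatter). A sulfonyl-type group alone therefore does not account for the change, since compound 1 carries such a group and gives 20700 nM.

Going by these compounds, it remains open which part counts, the lost methylene link or the sulfamoyl cap itself. On these data alone, how an acetyl cap on that ring nitrogen would read also stays open.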